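Swapping a five-membered ring for a brominated six-membered ring

The source may report more compounds than this note shows. Statements on the series, on what has been measured and on what is new or still open speak of the compounds shown alone.

Of the compounds shown here, three sharing one core have been measured in an assay on isolated protein for inhibition of Amine oxidase [flavin-containing] A (Homo sapiens), read by spectrophotometry; a lower number here means a stronger inhibitor, a higher number a weaker inhibitor. Compound 1 `COc1ccc(/C=N/Nc2nc3ccccc3nc2Cc2ccccc2)cc1` gives 63 nM in this assay. Compound 2 `CN(C)c1ccc(/C=N/Nc2nc3ccccc3nc2Cc2ccccc2)cc1` gives 83 nM. Compound 3 `C/C(=N\Nc1nc2ccccc2nc1Cc1ccccc1)c1cccs1` gives 64 nM. Compound 3 stands second highest of the three numbers, nearest to compound 1 and furthest from compound 2, yet both gaps lie within the scatter. Within the data shown here, the only step between measured compounds, dimethylamino in place of methoxy on an aromatic carbon, gave a 1.3-fold higher number from compound 1 to compound 2 (0.12 log units; within the scatter), so within this small set such a change has not moved the number beyond the scatter.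

Compound 4 `Brc1cccc(/C=N/Nc2nc3ccccc3nc2Cc2ccccc2)c1` has not yet been measured. It differs from compound 3 by a group of 9 heavy atoms (7 carbon, 1 nitrogen, 1 bromine; one six-membered aromatic ring of carbon only) in place of a group of 8 heavy atoms (6 carbon, 1 nitrogen, 1 sulfur; one five-membered aromatic ring with 1 hetero atom), on a nitrogen on an aromatic ring. Among the measured compounds shown here, no measured pair shows this exact change; the step from compound 1 to compound 2 is the nearest guide, and it concerns a smaller change on a different ring. On that basis no step beyond the scatter is expected, in either direction. Compound 4 is therefore expected to give about 60 nM in this assay, within a range from 20 nM to 180 nM. This estimate means a step of a 1.1-fold lower number from compound 3 to compound 4 (0.03 log units; within the scatter), expected to stay within the scatter.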

Compound 4, half-maximal inhibitory concentration: 9.8 nM
Compound 4: middle estimate off by 6.1-fold (0.79 log units), on the high side; the measured number lies below the stated range.
By their numbers in this assay, from the lowest: compound 4; then compounds 1, 3 and 2 (each within the scatter of the next).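

Compound 4 shows that the group on the carbon with a double bond to nitrogen can move the number in this assay, which compounds 1, 2 and 3 had not shown, since they all lay within the scatter of one another. With 3-bromophenyl in place of 4-methoxyphenyl the result is a 6.4-fold lower number from compound 1 to compound 4 (0.81 log units; beyond the scatter) and with 3-bromophenyl in place of 4-(dimethylamino)phenyl it is an 8.5-fold lower number from compound 2 to compound 4 (0.93 log units; beyond the scatter) while the exchange of the group holding the five-membered aromatic ring, on the nitrogen on an aromatic ring, gives a 6.5-fold lower number from compound 3 to compound 4 (0.81 log units; beyond the scatter) so compound 4 is the strongest inhibitor of the four, with every step to it beyond the scatter. Nothing available bears on why this change has such an effect.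

The compounds shown leave open whether the step belongs to the bromine or to where it stands on the six-membered ring, a question that plain phenyl, 4-bromophenyl and 3-chlorophenyl would address. They also leave open how this position would respond to a group of another kind, such as an amine or a carboxylic acid.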